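This account rests on a few compounds, and the source may have more. Where it says the series, first, only, none or still open, it means among the compounds named here.

Of the compounds shown here, three that share one core have been tested in an ADME assay on GES1 cells (Homo sapiens) for inhibition, read by MTT assay, with a stated time of 72 h; on this read-out lower numbers stand for stronger inhibition and higher numbers for weaker inhibition. Compound 1 `Cc1cc(Nc2cc(-c3ccccc3)[nH]n2)n2nc(SCc3c(Cl)cccc3Cl)nc2n1`, which carries 2,6-dichlorophenyl on a saturated chain carbon bound to a sulfur, gives 39600 nM. Compound 2 `Cc1cc(Nc2cc(-c3ccccc3)[nH]n2)n2nc(SCC3CCCCC3)nc2n1` gives no number, only a limit of the assay, > 50000 nM. Compound 3 `Cc1cc(Nc2cc(C(C)(C)C)[nH]n2)n2nc(SCc3ccc(Br)cc3)nc2n1` also gives only a limit, > 50000 nM. Compound 2 therefore stands at the limit of > 50000 nM in this assay, at which 2 of the 3 values shown sit, so its true value is not known.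

Compound 4 `Cc1cc(Nc2cc(-c3ccccc3)[nH]n2)n2nc(SCCCc3ccccc3)nc2n1` changes one group of compound 2: phenethyl in place of cyclohexyl on a saturated chain carbon bound to a sulfur. Phenethyl takes the place of cyclohexyl, and cut one bond further out, this reads cyclohexylmethyl to 3-phenylpropyl.

For the measured compounds named here, only one measured step involves this place on the chain: an at least 1.2-fold higher number from compound 1 to compound 2 (0.10 log units; that floor lies within the scatter). It is a floor and not a full measurement, so it gives only weak guidance. Compound 1 has an aromatic ring at the end of its chain and still gives only 39600 nM, so the aromatic ring entering compound 4 offers no reason to expect a large change. In this assay, the expected result is therefore no step beyond the scatter, and a number no higher from compound 2 to compound 4 (the limit leaves the size open) is an estimate with no firm direction. The estimated value for compound 4 is 50000 nM, with an expected range of 25000 nM to 100000 nM.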

Compound 4, half-maximal inhibitory concentration: 40200 nM
Estimate against measurement, compound 4: 1.2-fold (0.09 log units) above; the measured number falls inside the stated range.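

For the compounds shown here, compound 4 gives the first step at this place on the chain with a full number at both ends, a 1.0-fold higher number from compound 1 to compound 4 (0.01 log units; within the scatter), so in this assay phenethyl and 2,6-dichlorophenyl cannot be told apart, and the chlorine atoms of compound 1 are not needed for a number of this size. The step away from cyclohexyl, an at least 1.2-fold lower number from compound 2 to compound 4 (0.09 log units; that floor lies within the scatter), is only a floor, and that floor lies within the scatter. Its true size stays unknown because compound 2 gives no number, only a limit: the limit of > 50000 nM in this assay, at which 2 of the 4 values shown sit.

Going by these compounds, whether an amine or a carboxylic acid at the end of the chain, or a shorter chain ending in the same aromatic ring, would shift the number beyond the scatter stays open. On these data alone, it is also open whether phenethyl would read the same way on the tert-butyl version of the core, which compound 3 carries with a different group on the chain.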